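The source may hold more compounds than are shown below. What is called first, only, known or untested is meant among the compounds shown, and "the series" means these compounds.

Compound 1 `COc1ccccc1Oc1c(N)nc(-c2ccccc2)nc1Cl`: 4610 nM
Compound 2 `COc1ccccc1Oc1c(N)nc(-c2cccc(C)c2)nc1Cl`: 13100 nM
Compound 3 `COc1ccc(-c2nc(N)c(Oc3ccccc3OC)c(Cl)n2)cc1`: 47800 nM

These values come from a functional assay on B16 cells (Mus musculus) for cytotoxicity, read by CCK-8 assay, with a stated time of 24 h (a higher number here means a weaker inhibitor, a lower number a stronger inhibitor), where compound 3 stands highest of the three. Compound 4 `COc1ccccc1Oc1c(N)nc(-c2ccc(Cl)cc2)nc1Cl` carries chloro in place of methoxy on an aromatic carbon, para to a large group: chloro in place of methoxy on an aromatic carbon. Within the data shown here, no measured compound has a 4-chlorophenyl group, so only related steps can guide the expectation. Methyl in place of hydrogen gave a 2.8-fold higher number from compound 1 to compound 2 (0.45 log units; beyond the scatter), and methoxy in place of hydrogen gave a 10-fold higher number from compound 1 to compound 3 (1.02 log units; beyond the scatter). Exchanging one substituted ring for another gave a 3.6-fold higher number from compound 2 to compound 3 (0.56 log units; beyond the scatter). Methoxy gave the largest rise, so a modest fall on leaving it is expected. The expected change is a 3.0-fold lower number from compound 3 to compound 4 (0.48 log units; beyond the scatter). For compound 4 the estimated value is 16000 nM, with an expected range of 6000 nM to 40000 nM.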

Compound 4, half-maximal inhibitory concentration: 18800 nM
For compound 4 the middle estimate is 1.2-fold (0.07 log units) below the measured one; the measured number falls inside the stated range.
By their numbers in this assay, from the lowest: compound 1; then compounds 2 and 4 (each within the scatter of the next); then compound 3.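

In this assay, chloro in place of methoxy at this position gives (a 2.5-fold lower number from compound 3 to compound 4 (0.41 log units; beyond the scatter)), so the size of the rise depends on which group sits there. Chloro still stands apart from plain hydrogen (a 4.1-fold higher number from compound 1 to compound 4 (0.61 log units; beyond the scatter)), while the 4-chlorophenyl and 3-methylphenyl compounds cannot be told apart (a 1.4-fold higher number from compound 2 to compound 4 (0.16 log units; within the scatter)). Nothing measured here explains these shifts.

As far as these compounds go, how an amine, a carboxylic acid or a longer chain at this position would compare remains open.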